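Working notes on a 4-fluorophenyl for 2-chlorophenyl exchange

A few compounds are considered here, and "the series" means these few. Any claim that something is new, unique, unknown or untested is made for them only; others in the source may bear on it.

Measured so far:
compound 1, `CCCCc1cnc(C(CCC)Cc2ccc(-c3ccccc3C(=O)O)cc2)[nH]1`: 1180 nM
compound 2, `O=C(O)c1ccccc1-c1ccc(CCc2ncc(Cc3ccccc3Cl)[nH]2)cc1`: 292 nM
compound 3, `CCC(C)(C)Cc1c[nH]c(CCc2ccc(-c3ccccc3C(=O)O)cc2)n1`: 25 nM

All three were read in an in vitro functional assay on cells for agonist activity at Bombesin receptor subtype-3 (Homo sapiens), read by luminescence and calcium flux; a higher number here means that more compound is needed for the effect, a lower number that less compound is needed. Compound 2 stands second highest of the three numbers: compound 1 gives a number beyond the scatter above it, and compound 3 gives a number further beyond the scatter below it. Compound 4, `O=C(O)c1ccccc1-c1ccc(CCc2ncc(Cc3ccc(F)cc3)[nH]2)cc1`, has not yet been measured. It differs from compound 2 in one place: 4-fluorophenyl in place of 2-chlorophenyl on a saturated chain carbon bound to an aromatic carbon. Among the compounds with values here, no measured pair in the set differs by exactly this change, so no step is known for it; the three measured compounds differ from one another in several places at once and give no direct guide to the effect of this exchange. The step is therefore expected to be small, a 1.4-fold higher number from compound 2 to compound 4 (0.16 log units; within the scatter), possibly toward a higher number but not far beyond the scatter. In this assay compound 4 is estimated at 420 nM, with a range from 130 nM to 1400 nM.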

Compound 4, half-maximal effective concentration: 1600 nM
Compound 4: the middle estimate sits 3.8-fold (0.58 log units) below what was measured, outside the stated range (above it).
By their numbers in this assay, from the lowest: compound 3; then compound 2; then compounds 1 and 4 (each within the scatter of the next).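

In this assay, within the data shown here, the exchange of 2-chlorophenyl for 4-fluorophenyl on a saturated chain carbon bound to an aromatic carbon is the first single-place comparison, and it gives a 5.5-fold higher number from compound 2 to compound 4 (0.74 log units; beyond the scatter). This position therefore responds to the choice of substituted phenyl group, even though both groups have the same heavy-atom count, no hydrogen-bond donors or acceptors, and no net charge. No measurement at hand accounts for the size or direction of this step.

The step changes both the halogen and its location on the ring, and the compounds shown do not separate these two changes. Also open, on these data alone, is how a plain phenyl group or a pyridine ring would read on the same chain carbon.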